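Compound 3 to compound 4: morpholine amide

This account rests on a few compounds, and the source may have more. Where it says the series, first, only, none or still open, it means among the compounds named here.

Measured in an ADME assay on BE(2)-C cells (Homo sapiens) for cytotoxicity, read by MTT assay, with a stated time of 20 h; on this read-out lower numbers stand for higher toxicity in this test and higher numbers for lower toxicity in this test:
- compound 1 `CC(NC(=O)C1CCN(C(=O)c2cc3ccccc3n2Cc2ccc(Cl)cc2)CC1)c1ccncc1`: 90100 nM
- compound 2 `Cn1cnc(CNC(=O)C2CCN(C(=O)c3cc4ccccc4n3Cc3ccc(Cl)cc3)CC2)c1`: > 50000 nM (a limit)
- compound 3 `O=C(NCCCc1ccncc1)C1CCN(C(=O)c2cc3ccccc3n2Cc2ccc(Cl)cc2)CC1`: 71500 nM

In this assay compound 3 gives 71500 nM. For the measured compounds named here, its one readable step is a 1.3-fold lower number from compound 1 to compound 3 (0.10 log units; within the scatter). The value of compound 2 is only a limit, and a step that the limit leaves unreadable from compound 1 to compound 2 gives no size.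

Compound 4 `O=C(c1cc2ccccc2n1Cc1ccc(Cl)cc1)N1CCC(C(=O)N2CCOCC2)CC1` carries morpholin-4-yl in place of (3-(pyridin-4-yl)propyl)amino on a carbonyl carbon. Going by the values given here, the single sized step, a 1.3-fold lower number from compound 1 to compound 3 (0.10 log units; within the scatter), stays within the scatter, so no step beyond the scatter is expected in this assay. The expected step is a 1.1-fold higher number from compound 3 to compound 4 (0.05 log units; within the scatter). Compound 4 is estimated at 80000 nM, with an expected range of 45000 nM to 150000 nM.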

Compound 4, half-maximal cytotoxic concentration: > 100000 nM
Compound 4 ended at the assay's limit; the forecaster's own chance of this, stated with the estimate: 45%; middle value at least 1.2-fold (0.09 log units) from the limit.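

In this assay, compound 4 gives only a limit: the limit of > 100000 nM in this assay, at which 1 of the 4 values shown sits. It is the first compound shown with no aromatic ring and no hydrogen-bond donor in the group on this carbonyl carbon, and morpholin-4-yl gives no measured value there, only an at least 1.3-fold higher number from compound 3 to compound 4 (0.14 log units; that floor lies within the scatter) and an at least 1.1-fold higher number from compound 1 to compound 4 (0.04 log units; that floor lies within the scatter). Both are floors, and the step involving compound 2 cannot be read. Going by these compounds, the true size of the change therefore remains open, as does whether piperidin-1-yl or a carboxylic acid at this carbonyl carbon would give a readable value.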